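This account rests on a few compounds, and the source may have more. Where it says the series, first, only, none or still open, it means among the compounds named here.

Working notes on the series in an in vivo functional assay on the whole organism (brain) for inhibition of Norepinephrine transporter (Rattus norvegicus); on this read-out lower numbers stand for an effect already at smaller amounts and higher numbers for an effect only at larger amounts of compound.

Compound 1 `CN(C)C/C=C(/c1ccccc1)c1cccnc1` carries an unsubstituted phenyl and in this assay compound 1 gives 107 umol/kg. For the measured compounds named here, compound 2 `CN(C)C/C=C(/c1ccc(Cl)cc1)c1cccnc1` differs from compound 1 by a chloro in place of hydrogen on an aromatic carbon; in this assay compound 2 gives 38 umol/kg, and the step of a 2.8-fold lower number from compound 1 to compound 2 (0.45 log units; beyond the scatter) is the only measured step in the set. Compound 3 `CCNC/C=C(/c1ccc(Br)cc1)c1cccnc1` pairs a bromo on the aromatic ring with an ethylamino chain. For compound 3 this assay reports only a limit, > 102 umol/kg, so compound 3 sits at the weak end of the numbers shown, with no number of its own to compare against compound 1 or compound 2 (the limit of > 102 umol/kg in this assay, at which 1 of the 3 values shown sits).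

Compound 4 `CCCNC/C=C(/c1ccc(Br)cc1)c1cccnc1` is the next member: methyl in place of hydrogen on a saturated chain carbon, two bonds along the chain from an amine nitrogen, ethylamino becoming propylamino. Going by the values given here, no measured step touches the amine side of the molecule; the one measured step, from compound 1 to compound 2, concerns the aromatic ring and gives no guidance here. The working expectation is therefore a step that the limit leaves unreadable from compound 3 to compound 4 that is no larger than the scatter. Compound 4 is estimated at 150 umol/kg, within a range from 60 umol/kg to 400 umol/kg, with a real chance that this assay again returns only a limit.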

Compound 4, dose for half-maximal effect: > 95 umol/kg
Compound 4 ended at the assay's limit; the forecaster's own chance of this, stated with the estimate: 55%; the middle value does not contradict the limit.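

In this assay compound 3 gives > 102 umol/kg as a limit and not a number. Compound 4 likewise gives > 95 umol/kg as a limit, so no step can be read between compound 3 and compound 4. The compounds shown leave open whether ethylamino to propylamino changes the read-out in this assay at all.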